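Biaryl anilines in a Jurkat activation assay

This account rests on a few compounds, and the source may have more. Where it says the series, first, only, none or still open, it means among the compounds named here.

Measured compounds:
- compound 1 `CN1CCN(c2ccc(NCc3ccccc3O)cc2)CC1`: "not active" (no number reported)
- compound 2 `Oc1ccccc1CNc1ccc(N2CCNCC2)cc1`: "not active" (no number reported)
- compound 3 `Oc1ccccc1CNc1ccc(-c2ccc(Cl)cc2)cc1`: 2390 nM

Three compounds share a common core and were tested in a functional assay on Jurkat cells (Homo sapiens) for activation, with a stated time of 24 h; a lower number here means that less compound is needed, a higher number that more compound is needed for the effect. Compound 1 `CN1CCN(c2ccc(NCc3ccccc3O)cc2)CC1` gives "not active" (no number reported) in this assay, and compound 2 `Oc1ccccc1CNc1ccc(N2CCNCC2)cc1` gives "not active" (no number reported); neither carries a number. Among the compounds with values here, compound 3 `Oc1ccccc1CNc1ccc(-c2ccc(Cl)cc2)cc1` is the only one with a value in this assay, at 2390 nM, so it stands alone as the sole numerical point of reference, and no step between measured compounds can be stated.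

Compound 4 `Oc1ccccc1CNc1ccc(-c2ccc(OC(F)(F)F)cc2)cc1` has not yet been measured. It differs from compound 3 in one place: trifluoromethoxy in place of chloro on an aromatic carbon. Within the data shown here, with no comparable step among the measured compounds, nothing here gives a direction. The expectation is that the step from compound 3 to compound 4 in this assay stays within the usual scatter, a 1.0-fold higher number from compound 3 to compound 4 (0.02 log units; within the scatter), with no preference for either direction.

On that basis compound 4 is estimated at 2500 nM in this assay, with a range from 800 nM to 8000 nM.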

Compound 4, half-maximal effective concentration: "not active" (no number reported)
Nothing numeric was reported for compound 4, so the estimate cannot be set against anything.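

In this assay, within the data shown here, compound 4 gives "not active" (no number reported) while compound 3 gives 2390 nM and so, with a number on one side only, no step between compound 3 and compound 4 can be read. No measured evidence bears on this result. The compounds shown leave open which groups other than chloro on the shared core would give a number in this assay at all.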